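Swapping a Carboxy Group for a Hydroxyethyl Chain

The source may hold more compounds than are shown below. What is called first, only, known or untested is meant among the compounds shown, and "the series" means these compounds.

Compound 1 has the structure `CCCCCCCCc1ccc(CCC(N)(CO)C(=O)O)cc1`. In a functional assay on the whole organism (spleen, spleen) with Rattus norvegicus as the target (a higher number here means that more compound is needed for the effect, a lower number that less compound is needed), compound 1 gives > 10 mg/kg, which is a limit of the assay rather than a measured number. That figure is the limit of > 10 mg/kg in this assay, at which 1 of the 2 values shown sits. Compound 2 has the structure `CCCCCCCOc1ccc(CC[C@](N)(CO)CCO)cc1`, and in this assay compound 2 gives 4.2 mg/kg.

The unmeasured compound 3, `CCCCCCCCc1ccc(CCC(N)(CO)CCO)cc1`, keeps the core of compound 1 and differs from it in one change: 2-hydroxyethyl in place of carboxy on a saturated chain carbon bound to an amine nitrogen and two saturated chain carbons. Among the measured compounds shown here, no measured pair covers this exact change, so the expectation rests on compound 2, which carries the same 2-hydroxyethyl group and gives 4.2 mg/kg. Compound 3 is expected to fall in the measurable range, with the step of an at least 3.3-fold lower number from compound 1 to compound 3 (0.52 log units; beyond the scatter) estimated to run toward lower doses beyond the usual scatter. Compound 3 is estimated at 3 mg/kg, within a range from 1 mg/kg to 9 mg/kg.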

Compound 3, dose for 50% inhibition: 0.009 mg/kg
For compound 3 the middle estimate is 330-fold (2.52 log units) above the measured one, outside the stated range (below it).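

In this assay, putting 2-hydroxyethyl in place of carboxy on this carbon, with the rest of compound 1 unchanged, gives an at least 1100-fold lower number from compound 1 to compound 3 (3.04 log units; beyond the scatter). Among the compounds shown here, this is the first direct comparison of the two groups at this position, and it shows that this one exchange can change the required dose greatly, even though the two groups match in heavy-atom, hydrogen-bond donor and hydrogen-bond acceptor counts. The figure for compound 1 is a limit, so the full size of the step stays unknown: the limit of > 10 mg/kg in this assay, at which 1 of the 3 values shown sits.

From the compounds shown here alone, it remains open how an amide or a longer hydroxyalkyl chain on this carbon would compare with 2-hydroxyethyl. Going by these compounds, it is also open whether the same exchange would give a step of similar size on a different core.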